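The source may hold more compounds than are shown below. What is called first, only, known or untested is meant among the compounds shown, and "the series" means these compounds.

Measured so far:
compound 1, `CCC(=O)Nc1c(C(O)(C(F)(F)F)C(F)(F)F)ccc2ccccc12`: 15 nM
compound 2, `CCC(CC)C(=O)Nc1c(C(O)(C(F)(F)F)C(F)(F)F)ccc2ccccc12`: 4340 nM
compound 3, `COCC(=O)Nc1c(C(O)(C(F)(F)F)C(F)(F)F)ccc2ccccc12`: 213 nM

All three share one core and differ only in the group on the carbonyl carbon of the amide, and all were tested in an assay on LtK cells with ATP-sensitive inward rectifier potassium channel 11 (Homo sapiens) as the target; on this read-out lower numbers stand for an effect already at smaller amounts and higher numbers for an effect only at larger amounts of compound. Compound 2 gives the highest number of the three: there was a 290-fold higher number from compound 1 to compound 2 (2.46 log units; beyond the scatter), and a 20-fold lower number from compound 2 to compound 3 (1.31 log units; beyond the scatter). Compound 4, `O=C(Nc1c(C(O)(C(F)(F)F)C(F)(F)F)ccc2ccccc12)c1cccc([N+](=O)[O-])c1`, has not been measured; it differs from compound 2 by 3-nitrophenyl in place of pentan-3-yl on a carbonyl carbon. The two measured steps show that a small or a chain-with-one-oxygen group on the carbonyl carbon gives a far lower number than pentan-3-yl, so a downward step from compound 2 to compound 4 is expected, though a ring is new here. The estimate for compound 4 is 300 nM, within 30 nM to 3000 nM, an expected step of a 14-fold lower number from compound 2 to compound 4 (1.16 log units; beyond the scatter).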

Compound 4, half-maximal effective concentration: 117 nM
For compound 4 the middle estimate is 2.6-fold (0.41 log units) above the measured one; measured number inside the range.
By their numbers in this assay, from the lowest: compound 1; then compounds 4 and 3 (each within the scatter of the next); then compound 2.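

A ring can sit on the carbonyl carbon without the large rise seen with pentan-3-yl, even though 3-nitrophenyl has more heavy atoms (a 37-fold lower number from compound 2 to compound 4 (1.57 log units; beyond the scatter)). Its number cannot be told apart from that of the methoxymethyl group (a 1.8-fold lower number from compound 3 to compound 4 (0.26 log units; within the scatter)), but it does not reach the low number of the small ethyl group (a 7.8-fold higher number from compound 1 to compound 4 (0.89 log units; beyond the scatter)). Nothing available explains these differences.

Still open, as far as these compounds go, is how a plain phenyl ring would compare, or a ring carrying an amine or a carboxylic acid in place of the nitro group. The part played by the ring and the part played by the nitro group therefore cannot yet be separated.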